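The source may hold more compounds than are shown below. What is called first, only, known or untested is meant among the compounds shown, and "the series" means these compounds.

In a functional assay on HCT-116 cells (Homo sapiens) for cytotoxicity, read by MTT assay, with a stated time of 72 h (a higher number here means a weaker inhibitor, a lower number a stronger inhibitor), two compounds that share one core have been measured so far. Compound 1 `O=C1c2c[n+]([O-])c3ccccc3c2C(=O)c2c1c1ccccc1n2Cc1cn(CC(O)CO)nn1`, which carries a 1,2-dihydroxyethyl group on a saturated chain carbon, gives 250 nM. Compound 2 `CC1(C)OC[C@@H](Cn2cc(Cn3c4c(c5ccccc53)C(=O)c3c[n+]([O-])c5ccccc5c3C4=O)nn2)O1`, with 2,2-dimethyl-1,3-dioxolan-4-yl in place of that group, gives 340 nM. Compound 2 therefore stands level with compound 1, as the two numbers lie within the scatter of each other.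

Compound 3 `O=C1c2c[n+]([O-])c3ccccc3c2C(=O)c2c1c1ccccc1n2Cc1cn([C@H]2C[C@H](O)[C@@H](CO)O2)nn1` keeps the core but differs from compound 2 on an aromatic nitrogen of the five-membered aromatic ring with 3 nitrogen: 4-hydroxy-5-(hydroxymethyl)oxolan-2-yl in place of (2,2-dimethyl-1,3-dioxolan-4-yl)methyl on an aromatic nitrogen.

Going by the values given here, only one measured step bears on this change: a 1.4-fold higher number from compound 1 to compound 2 (0.13 log units; within the scatter). It lies within the scatter and involves the same part of the molecule, so no step beyond the scatter is expected in this assay. This is thin evidence, as neither measured compound has a ring bound directly to that aromatic nitrogen, and the range must stay wide. The expected step is a 1.1-fold lower number from compound 2 to compound 3 (0.05 log units; within the scatter). Compound 3 is estimated at 300 nM, with an expected range of 100 nM to 900 nM.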

Compound 3, half-maximal inhibitory concentration: 120 nM
Compound 3: middle estimate off by 2.5-fold (0.40 log units), on the high side; low and high end bracket the measured number.
By their numbers in this assay, from the lowest: compound 3; then compounds 1 and 2 (each within the scatter of the next).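

In this assay, the earlier change on this side chain left the number within the scatter, but 4-hydroxy-5-(hydroxymethyl)oxolan-2-yl on the aromatic nitrogen gives a 2.8-fold lower number from compound 2 to compound 3 (0.45 log units; beyond the scatter) and a 2.1-fold lower number from compound 1 to compound 3 (0.32 log units; beyond the scatter). Both steps are modest but lie beyond the scatter, so this position can respond to a change of substituent, and the response appears against both the open 2,3-dihydroxypropyl chain and the (2,2-dimethyl-1,3-dioxolan-4-yl)methyl group. No measurement here gives a reason for the lower number in compound 3.

Compound 3 differs from compound 2 in its ring, its hydrogen-bond donors and acceptors, and its defined stereocentres all at once, so these compounds cannot show which of these differences matters. A plain oxolan-2-yl group, or the same ring with an amine in place of a hydroxy group, would help to separate the contribution of the ring from that of its substituents.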